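The compounds below may be only part of what the source reports. "The series", "measured", "known", "first", "only" and "open" are said of these compounds alone.

Working notes on the series. The shared core of compound 1 `COc1ccc2[nH]c3c(c2c1)CCNC31CCN(Cc2ccccc2)CC1` carries a benzyl group on the ring amine nitrogen; in an assay on FRT cells for positive allosteric modulation of Cystic fibrosis transmembrane conductance regulator variant N1303K (Homo sapiens), in the presence of a further agent that is not named here (a lower number here means that less compound is needed, a higher number that more compound is needed for the effect), compound 1 gives 12600 nM. Compound 2 `COc1ccc2[nH]c3c(c2c1)CCNC31CCN(Cc2ccc(Br)c(F)c2)CC1` differs only in the benzyl ring, and in this assay compound 2 gives 1800 nM. Compound 3 `COc1ccc2[nH]c3c(c2c1)CCNC31CCN(Cc2c(F)c(F)c(F)c(F)c2F)CC1` carries the fully fluorinated ring, and in this assay compound 3 gives 2100 nM. Among the three numbers compound 2 stands lowest, with compound 3 close to it within the scatter and compound 1 clearly higher. For the measured compounds named here, the one single-point step that is fully characterised is a 7.0-fold lower number from compound 1 to compound 2 (0.85 log units; beyond the scatter), showing that halogen substitution on the benzyl ring lowers the number substantially.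

Compound 4 `COc1ccc2[nH]c3c(c2c1)CCNC31CCN(Cc2ccc(F)c(F)c2)CC1` is not yet measured. Relative to compound 2 the change is fluoro in place of bromo on an aromatic carbon. Going by the values given here, no measured step exchanges one halogen for another on this ring; the step from compound 1 to compound 2 only shows that the halogenated ring is better than the bare one, and compound 3 shows that a different halogen pattern lands near compound 2. The retained fluoro and the remaining halogen-bearing ring suggest compound 4 stays well below compound 1, with a small upward drift expected because the bromo of compound 2 with 1800 nM is removed. The expected step is a 1.7-fold higher number from compound 2 to compound 4 (0.22 log units; within the scatter). For compound 4 the estimate in this assay is 3000 nM, with a range of 1200 nM to 8000 nM.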

Compound 4, half-maximal effective concentration: 11000 nM
Compound 4: the middle estimate sits 3.7-fold (0.56 log units) below what was measured, and the stated range ends below it.
By their numbers in this assay, from the lowest: compounds 2 and 3 (each within the scatter of the next); then compounds 4 and 1 (each within the scatter of the next).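

In this assay the bromo on this aromatic carbon, para to a large group and ortho to a fluoro group, matters to the number: fluoro in its place gives a 6.1-fold higher number from compound 2 to compound 4 (0.79 log units; beyond the scatter) and so removes the gain seen with the 4-bromo-3-fluorophenyl ring. Set against the bare ring, the 3,4-difluorophenyl ring gives a 1.1-fold lower number from compound 1 to compound 4 (0.06 log units; within the scatter) and lies within the scatter, so for this pair a halogen on the ring is not enough to lower the number, and the gain in compound 2 goes with bromo at this position rather than with the retained fluoro. This reading holds only for the position named, since compound 3 with its fully fluorinated ring gives 2100 nM and differs from compound 2 in more than one place, so it does not test the same change.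

From the compounds shown here alone, whether bromo itself is required stays open, and chloro, iodo, methyl or trifluoromethyl on the same carbon would show how specific the effect is. Nothing among the data shown accounts for the difference between bromo and fluoro here.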